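The source may hold more compounds than are shown below. What is called first, only, known or untested is meant among the compounds shown, and "the series" means these compounds.

Measured so far in an ADME assay on microsomes from liver (Rattus norvegicus) for metabolic stability; on this read-out lower numbers stand for a shorter-lived compound and higher numbers for a longer-lived compound:
compound 1, `CC#C[C@@H](Cc1nnn[nH]1)c1ccc(OCc2ccc3scc(-c4ccccc4C(F)(F)F)c3c2)cc1`, gives 0.167 h.
compound 2, `CC#C[C@@H](Cc1nnn[nH]1)c1ccc(OCc2ccc3sc(C(F)(F)F)c(-c4ccc(OCCOC)cc4C)c3c2)cc1`, comes back from this assay only as a limit, > 3 h.

Compound 2 therefore stands at the ceiling of the numbers shown: its result is a limit, not a measured number, and how far past that mark it really lies is unknown (the limit of > 3 h in this assay, at which 1 of the 2 values shown sits). Compound 1 sits at the short-lived end, but it differs from compound 2 in several places at once, so it gives no guide for a single change.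

The unmeasured compound 3, `CC#C[C@@H](Cc1nnn[nH]1)c1ccc(OCc2ccc3sc(C)c(-c4ccc(OCCOC)cc4C)c3c2)cc1`, differs from compound 2 in one place only: methyl in place of trifluoromethyl on an aromatic carbon. Within the data shown here, no measured pair isolates this change, so the expectation rests on the position of compound 2 alone. A moderate shortening is expected, a step of an at least 2.5-fold lower number from compound 2 to compound 3 (0.39 log units; beyond the scatter) in this assay, which would bring the half-life back into the measurable range. Compound 3 is estimated at 1.2 h in this assay, within a likely range from 0.3 h to 3 h, with a real chance that the read-out is again reported only as a limit.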

Compound 3, half-life: 0.117 h
Compound 3: the middle estimate sits 10-fold (1.01 log units) above what was measured; the whole stated range lies above it.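

In this assay, the aromatic carbon next to the ring sulfur proves highly sensitive to what it carries: putting methyl in place of trifluoromethyl there gives an at least 25-fold lower number from compound 2 to compound 3 (1.40 log units; beyond the scatter). Among these compounds, this is the first comparison here that differs in one place only, so the drop belongs to this single replacement, with the 4-(2-methoxyethoxy)-2-methylphenyl group and the rest of the structure unchanged. Compound 2 is reported only as a limit, so the step gives a smallest possible size rather than a true one: the limit of > 3 h in this assay, at which 1 of the 3 values shown sits.

The compounds shown leave open how other groups on this carbon, such as a chlorine atom, an ethyl or a cyclopropyl, would fall in this assay, and so whether a long half-life here requires trifluoromethyl itself or could also be reached with another group. Among the compounds shown here, they also leave open whether the same replacement would give a step of similar size in a compound carrying something other than the 4-(2-methoxyethoxy)-2-methylphenyl group, as this single pair is the only evidence on the change.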